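The source may hold more compounds than are shown below. What is called first, only, known or untested is meant among the compounds shown, and "the series" means these compounds.

Compound 1 has the structure `CCCC1([C@H](O)/C=C/C2[C@H](O)CC(=O)[C@@H]2C/C=C\CCCC(=O)O)CCC1`. In a functional assay on the whole organism (strain Hartley) for inhibition, with Cavia porcellus as the target, with stated times of 15 min and 2 min (on this read-out higher numbers stand for an effect only at larger amounts of compound and lower numbers for an effect already at smaller amounts), compound 1 gives 0.003 mg/kg, and compound 2, with the structure `CCCCC1([C@@H](O)/C=C/C2CCC(=O)[C@@H]2CCCCCCC(=O)OCC)CCC1`, gives 0.00206 mg/kg, a number that lies within the usual scatter of compound 1, so the two cannot be told apart. Compound 3, with the structure `CCCCC1([C@H](O)/C=C/C2[C@H](O)CC(=O)[C@@H]2C/C=C\CCCC(=O)O)CCC1`, has not yet been measured. It differs from compound 1 by methyl in place of hydrogen on a saturated chain carbon, three bonds along the chain from a saturated ring carbon. Among the compounds with values here, no measured pair shows this change alone. Compound 2 carries the longer chain together with other changes and sits within the scatter of compound 1, so the step from compound 1 to compound 3 is expected to be no change at the digits printed from compound 1 to compound 3 (within the scatter), nothing beyond the scatter. Compound 3 is therefore estimated at 0.003 mg/kg, with a range from 0.0012 mg/kg to 0.0075 mg/kg.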

Compound 3, dose for half-maximal effect: 0.00106 mg/kg
Estimate against measurement, compound 3: 2.8-fold (0.45 log units) above; the measured number lies below the stated range.
By their numbers in this assay, from the lowest: compounds 3, 2 and 1 (each within the scatter of the next, the first and the last beyond it).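

Going from propyl to butyl, on a saturated chain carbon, three bonds along the chain from a saturated ring carbon, gives the first reading of this change on its own: in this assay the number falls, with a 2.8-fold lower number from compound 1 to compound 3 (0.45 log units; beyond the scatter). This single added methyl is enough to shift the dose, and the position accepts the longer chain without loss. Nothing measured here accounts for this shift.

On these data alone, whether a pentyl or still longer chain would lower the number further remains open. So does the effect of a phenyl ring or a terminal hydroxyl at this chain end.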